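The compounds below may be only part of what the source reports. "The series", "measured", "known", "first", "only" and "open" are said of these compounds alone.

Measured in a functional assay on SK-BR-3 cells (Homo sapiens) for cytotoxicity, read by MTT assay, with a stated time of 72 h; on this read-out higher numbers stand for an effect only at larger amounts of compound and lower numbers for an effect already at smaller amounts:
compound 1 `O=c1cc(NC2CC2)cc(-c2ccccc2)o1` gives > 30 uM;
compound 2 `O=c1cc(Nc2ccccc2)cc(-c2ccccc2)o1` gives 0.13 uM;
compound 3 `COc1ccc(Nc2cc(-c3ccccc3)oc(=O)c2)cc1` gives 0.079 uM.

The value of compound 1 is a limit, (the limit of > 30 uM in this assay, at which 1 of the 3 values shown sits). Of the two numbers, compound 3 stands lowest; its nearest neighbour is compound 2, and a 1.6-fold lower number from compound 2 to compound 3 (0.22 log units; within the scatter) lies within the scatter. Within the data shown here, the only large step in the set, an at least 230-fold lower number from compound 1 to compound 2 (2.36 log units; beyond the scatter), concerns the group on the nitrogen and not the aromatic carbon. Compound 4 `O=c1cc(Nc2ccc(Br)cc2)cc(-c2ccccc2)o1` differs from compound 3 by bromo in place of methoxy on an aromatic carbon. The step that bears on it is the methoxy step from compound 2 to compound 3, which stayed within the scatter, so in this assay no step beyond the scatter is expected, a 1.3-fold higher number from compound 3 to compound 4 (0.10 log units; within the scatter). Compound 4 is therefore estimated at 0.1 uM, between 0.035 uM and 0.3 uM.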

Compound 4, concentration for half-maximal effect: 0.4 uM
For compound 4 the middle estimate is 4.0-fold (0.60 log units) below the measured one; the whole stated range lies below it.
By their numbers in this assay, from the lowest: compounds 3 and 2 (each within the scatter of the next); then compound 4. At a limit, above all of these: compound 1.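

On the aromatic carbon para to a large group, the choice of group now counts: bromo in place of methoxy gives a 5.1-fold higher number from compound 3 to compound 4 (0.70 log units; beyond the scatter) and bromo in place of hydrogen gives a 3.1-fold higher number from compound 2 to compound 4 (0.49 log units; beyond the scatter) while methoxy in place of hydrogen had stayed within the scatter. On the nitrogen, 4-bromophenyl in place of cyclopropyl still gives an at least 75-fold lower number from compound 1 to compound 4 (1.87 log units; beyond the scatter) so the large step survives the bromo. Compound 1 remains a limit: the limit of > 30 uM in this assay, at which 1 of the 4 values shown sits.

On these data alone, only hydrogen, methoxy and bromo are compared at this carbon, so whether an amine, a carboxylic acid or a longer chain such as ethoxy would follow methoxy or bromo stays open. Why bromo differs from methoxy cannot be told from these numbers.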